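This account rests on a few compounds, and the source may have more. Where it says the series, first, only, none or still open, it means among the compounds named here.

Going by the values given here, compound 2, `CNC1=CC(=O)c2cc(C)ncc2C1=O`, holds the lowest of the two numbers measured so far in a functional assay on cells (Homo sapiens) for cytotoxicity, read by propidium iodide staining, with a stated time of 4 days (a higher number here means a weaker inhibitor, a lower number a stronger inhibitor), where compound 2 gives 350 nM. Among the compounds with values here, the only other compound, compound 1, `CNC1=CC(=O)c2c(cnc(C)c2C)C1=O`, gives 2440 nM in this assay, and the single step measured so far is a 7.0-fold lower number from compound 1 to compound 2 (0.84 log units; beyond the scatter). Compound 3, `Cc1cc2c(cn1)C(=O)C(NCl)=CC2=O`, has not yet been measured. Its difference from compound 2 is chloro in place of methyl on an amine nitrogen. Within the data shown here, the one measured step, from compound 1 to compound 2, concerns hydrogen in place of methyl on an aromatic carbon, a different place and a different exchange, so it does not bear directly on the change from compound 2 to compound 3. Among the measured compounds shown here, with no measured step of this kind, there is no ground for expecting a shift in either direction beyond the scatter in this assay, and the estimate rests on the value of compound 2 alone, with a wide range to reflect that uncertainty. Compound 3 is therefore expected at 500 nM, with a range from 100 nM to 3000 nM. That expectation amounts to a step of a 1.4-fold higher number from compound 2 to compound 3 (0.15 log units; within the scatter).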

Compound 3, half-maximal inhibitory concentration: 360 nM
Estimate against measurement, compound 3: 1.4-fold (0.14 log units) above; the measured number falls inside the stated range.
By their numbers in this assay, from the lowest: compounds 2 and 3 (each within the scatter of the next); then compound 1.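

In this assay the exchange at the amine nitrogen gives a 1.0-fold higher number from compound 2 to compound 3 (0.01 log units; within the scatter) and so puts compound 2 and compound 3 level within the scatter. Going by these compounds alone, the only earlier step concerned a methyl group on an aromatic carbon, so this is the first reading at the nitrogen, and it shows that a methyl group and a chloro group, each a single heavy atom with no hydrogen-bond donors, acceptors or net charge, can occupy this place with no difference that this assay can resolve. Nothing measured here explains why the two numbers agree.

From the compounds shown here alone, one exchange at one position is a narrow view, so it remains open whether the same agreement would hold for a larger group on this nitrogen, such as a longer chain like propyl, a hydroxyethyl chain or a chain ending in a carboxylic acid. Going by these compounds, it is also open whether chloro in place of methyl on this nitrogen would behave the same way on the core of compound 1, which carries an extra methyl group on an aromatic carbon.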